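The source may report more compounds than this note shows. Statements on the series, on what has been measured and on what is new or still open speak of the compounds shown alone.

Three compounds have numbers in a functional assay on MIA PaCa-2 cells (Homo sapiens) for inhibition, read by MTT assay, with a stated time of 72 h; on this read-out lower numbers stand for stronger inhibition of growth and higher numbers for weaker inhibition of growth. Compound 1 `CCCCc1ccc(S(=O)(=O)NCCCCCCNCc2ccc(Br)cc2)cc1` gives 5700 nM. For the measured compounds named here, compound 3 `O=S(=O)(NCCCCCCNCc1ccc(Br)cc1)c1ccc(C(F)(F)F)cc1` gives 3830 nM; the only single-point step measured so far, a 1.5-fold lower number from compound 1 to compound 3 (0.17 log units; within the scatter), is within the scatter. Compound 2 `COc1cccc(CNCCCNS(=O)(=O)c2cc(C(F)(F)F)cc(C(F)(F)F)c2)c1` gives 3400 nM, the lowest of the three numbers, though its distance from compound 3 and from compound 1 both lie within the scatter, so no order among the three can be read.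

Compound 4 `COc1ccc(CNCCCNS(=O)(=O)c2cc(C(F)(F)F)cc(C(F)(F)F)c2)cc1` has the same atoms as compound 2, joined differently: 4-methoxyphenyl in place of 3-methoxyphenyl on a saturated chain carbon bound to an amine nitrogen. Going by the values given here, no measured step changes where the methoxy group sits; the step from compound 1 to compound 3 concerns a different group at a different place and was itself within the scatter, so it offers no lead on direction or size. With nothing in the measured numbers to push either way, the expected step in this assay is no change at the digits printed from compound 2 to compound 4 (within the scatter), nothing beyond the scatter. Compound 4 is estimated at 3400 nM, with a range of 1700 nM to 6800 nM.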

Compound 4, concentration for 50% growth inhibition: 2500 nM
Compound 4: middle estimate off by 1.4-fold (0.13 log units), on the high side; the measured number falls inside the stated range.
By their numbers in this assay, from the lowest: compounds 4, 2, 3 and 1 (each within the scatter of the next, the first and the last beyond it).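

Moving the methoxy group on the benzyl end of the shared core, with 4-methoxyphenyl in place of 3-methoxyphenyl on a saturated chain carbon bound to an amine nitrogen, gives in this assay a 1.4-fold lower number from compound 2 to compound 4 (0.13 log units; within the scatter) and stays within the scatter. The earlier step concerned only the trifluoromethyl and butyl groups at the other end, whereas this one shows that 3-methoxybenzyl and 4-methoxybenzyl cannot be told apart in this read-out of growth inhibition. No measurement offering an explanation for this result is at hand.

From the compounds shown here alone, whether an amine or a carboxylic acid in place of methoxy on this ring would move the number beyond the scatter remains open. Compound 1 and compound 4 differ in more than one place, so no single change can account for the gap between them.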